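Swapping Fluoro for Trifluoromethyl: An Expected Lipophilicity Step

This account rests on a few compounds, and the source may have more. Where it says the series, first, only, none or still open, it means among the compounds named here.

Measured in a physicochemical assay for lipophilicity; a higher number here means a more lipophilic compound, a lower number a more polar compound:
- compound 1 `Fc1ccccc1C1=NC(c2ccccc2)CO1`: 3.51
- compound 2 `Fc1cccc(Cl)c1C1=NC(c2ccccc2)CO1`: 3.45
- compound 3 `FC(F)(F)c1ccccc1-c1ncco1`: 2.15

Compound 1 stands level with compound 2 within the scatter, and its value lies clearly higher than that of compound 3. Compound 4 `FC(F)(F)c1ccccc1C1=NC(c2ccccc2)CO1` keeps the core of compound 1 but has trifluoromethyl in place of fluoro on an aromatic carbon, ortho to a large group: trifluoromethyl in place of fluoro on an aromatic carbon.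

Among the measured compounds shown here, only one measured step links compounds with this core: a number 0.06 log units lower from compound 1 to compound 2 (within the scatter). That step is a different swap, chloro in place of hydrogen, so it offers only weak guidance. For the measured compounds named here, compound 3 also carries trifluoromethyl, but its core differs, so its value of 2.15 gives no step for this swap. What enters is a larger group with no hydrogen-bond donors or acceptors, so a moderate rise is expected in this assay. The expected step is a number 0.49 log units higher from compound 1 to compound 4 (beyond the scatter), and this remains an estimate. For compound 4 the estimated value is 4, within an expected range of 3.6 to 4.4.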

Compound 4, partition coefficient: 3.71
Compound 4: the middle estimate sits 0.29 log units above what was measured, within the range that was stated.
By their numbers in this assay, from the lowest: compound 3; then compounds 2, 1 and 4 (each within the scatter of the next).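

In this assay, among the compounds shown here, this is the first direct reading of trifluoromethyl in place of fluoro on an aromatic carbon, ortho to a large group, and it gives a number 0.20 log units higher from compound 1 to compound 4 (within the scatter). Four heavy atoms thus replace one at this position, neither group has hydrogen-bond donors or acceptors, and compound 1 and compound 4 stand level. No measurement here offers an explanation for this result.

On these data alone, whether an amine or a carboxylic acid at this position would move the number beyond the scatter remains open, as does the effect of a longer chain there. It is also unknown whether the same swap would give a similar step on another core, since compound 3 has no fluoro partner among the compounds shown.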